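Aryl sulfonamide swap on the shared core, compound 3 to 4

A few compounds are considered here, and "the series" means these few. Any claim that something is new, unique, unknown or untested is made for them only; others in the source may bear on it.

Measured so far:
Compound 1 `CCOC(=O)c1oc2ccc(NS(=O)(=O)c3ccc(Br)cc3)cc2c1C` gives in a functional assay on HCT-116 cells (Homo sapiens) for inhibition, read by MTT assay, with a stated time of 72 h (a lower number here means a stronger inhibitor, a higher number a weaker inhibitor), a limit of > 40000 nM.
Compound 2 `CCOC(=O)c1oc2ccc(N(Cc3ccccc3)S(=O)(=O)c3cccc(Br)c3)cc2c1C` gives in this assay a limit of > 40000 nM.
Compound 3 `CCOC(=O)c1oc2ccc(N(Cc3ccccc3)S(=O)(=O)c3ccccc3Br)cc2c1C` gives in this assay a limit of > 40000 nM.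

Compound 3 therefore stands only at a limit in this assay, as do the two other measured members of the series, which is summed up by the limit of > 40000 nM in this assay, at which 3 of the 3 values shown sit. Within the data shown here, the one step that changes a single place, a step that the two limits leave unreadable from compound 2 to compound 3, cannot be read because both ends are limits. Compound 4 `CCOC(=O)c1oc2ccc(N(Cc3ccccc3)S(=O)(=O)c3ccc([N+](=O)[O-])cc3)cc2c1C` is not yet measured; it differs from compound 3 by 4-nitrophenyl in place of 2-bromophenyl on a sulfonyl sulfur. Among the measured compounds shown here, no measured step bears readably on this change, since every value in this assay sits at the same limit. Nothing in the numbers shown argues for a step beyond the scatter, so the expected step that the limit leaves unreadable from compound 3 to compound 4 is no readable change. Compound 4 is therefore estimated in this assay at 60000 nM, with a range from 20000 nM to 200000 nM, most likely reported again only as a limit.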

Compound 4, half-maximal inhibitory concentration: > 40000 nM
Compound 4 was reported as a limit (the forecaster's own chance of this, stated with the estimate: 80%); the middle value does not contradict the limit.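

In this assay, among these compounds, compound 4 gives > 40000 nM, a limit, so no step from compound 2 or compound 3 to compound 4 can be read. The series rests at a single limit: the limit of > 40000 nM in this assay, at which 4 of the 4 values shown sit.

The compounds shown leave open whether any aryl group on the sulfonyl sulfur of the shared core gives a number rather than a limit in this assay.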